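This account rests on a few compounds, and the source may have more. Where it says the series, first, only, none or still open, it means among the compounds named here.

- compound 1 `O=C(/C=C/c1cccc(F)c1)Nc1ccc(CC2=CC(=O)OC2)cc1` gives 49000 nM in a functional assay on HeLa cells (Homo sapiens) for cytotoxicity, read by MTT assay, with a stated time of 48 h; a lower number here means a stronger inhibitor, a higher number a weaker inhibitor
- compound 2 `O=C(/C=C/c1ccccc1F)Nc1ccc(CC2=CC(=O)OC2)cc1` gives 45800 nM in this assay

Among the compounds with values here, compound 2 sits level with compound 1, the only other measured compound, and the two lie within the scatter of repeated measurements. Compound 3 `O=C(/C=C/c1ccc(F)cc1)Nc1ccc(CC2=CC(=O)OC2)cc1` keeps the shared core of compound 2 but carries 4-fluorophenyl in place of 2-fluorophenyl (4-fluorophenyl in place of 2-fluorophenyl on a double-bonded chain carbon bound to a double-bonded chain carbon). Within the data shown here, the only measured step that bears on this swap is the exchange of 3-fluorophenyl for 2-fluorophenyl (a 1.1-fold lower number from compound 1 to compound 2 (0.03 log units; within the scatter)), which stayed within the scatter. On that single precedent, no step beyond the scatter is expected in this assay (a 1.0-fold higher number from compound 2 to compound 3 (0.01 log units; within the scatter)). Compound 3 is expected at 47000 nM (estimated range 20000 nM to 100000 nM).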

Compound 3, half-maximal inhibitory concentration: > 50000 nM
Compound 3 ended at the assay's limit; the forecaster's own chance of this, stated with the estimate: 10%; middle value at least 1.0-fold (0.02 log units) from the limit.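

With 4-fluorophenyl, all three fluorophenyl forms in this series have now been read in this assay, and compound 3 gives a limit of the assay, not a number: the limit of > 50000 nM in this assay, at which 1 of the 3 values shown sits. The steps are an at least 1.0-fold higher number from compound 2 to compound 3 (0.03 log units; that floor lies within the scatter) and an at least 1.0-fold higher number from compound 1 to compound 3 (0.00 log units; that floor lies within the scatter). Neither floor lies beyond the scatter, so moving the fluorine around this ring has produced no measurable separation, although the true gap to compound 3 could be larger.

From the compounds shown here alone, how far compound 3 lies past the limit stays open. So does the effect of 4-chlorophenyl or 4-methoxyphenyl at this place.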